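This account rests on a few compounds, and the source may have more. Where it says the series, first, only, none or still open, it means among the compounds named here.

Compound 1 `O=C(NCc1cn(Cc2ccc(C(F)(F)F)cc2)nn1)c1cn(-c2ccccc2)nc1-c1ccccc1` in a functional assay on MCF7 cells (Homo sapiens) for antiproliferative activity, read by sulforhodamine B assay, with a stated time of 48 h (a higher number here means a weaker inhibitor of growth, a lower number a stronger inhibitor of growth), gives 840 nM.
Compound 2 `COc1ccc(Cn2cc(CNC(=O)c3cn(-c4ccccc4)nc3-c3ccccc3)nn2)cc1OC` in this assay gives 12600 nM.

Compound 2 holds the higher of these two numbers; compound 1 stands nearest, and the measured step is a 15-fold higher number from compound 1 to compound 2 (1.18 log units; beyond the scatter). Compound 3 `COc1ccc(Cn2cc(CNC(=O)c3cn(-c4ccccc4)nc3-c3ccc(F)cc3)nn2)cc1OC` differs from compound 2 by fluoro in place of hydrogen on an aromatic carbon. For the measured compounds named here, the only measured step concerns a different part of the molecule, the group on a saturated chain carbon bound to an aromatic nitrogen, so nothing measured bears directly on this change. The step of a 1.3-fold lower number from compound 2 to compound 3 (0.10 log units; within the scatter) is therefore expected to stay within the scatter, with no clear direction. Compound 3 is estimated at 10000 nM, in a range from 4000 nM to 30000 nM.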

Compound 3, concentration for 50% growth inhibition: > 100000 nM
Compound 3: a limit, no number (the forecaster's own chance of this, stated with the estimate: 10%); middle value at least 10-fold (1.00 log units) from the limit.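

In this assay compound 3 gives > 100000 nM, a limit of the assay and not a number. Adding one fluoro, phenyl to 4-fluorophenyl, is a small change, yet it brings an at least 7.9-fold higher number from compound 2 to compound 3 (0.89 log units; beyond the scatter), meaning weaker growth inhibition. So this position matters too, whereas the earlier step spoke only to the group on a saturated chain carbon bound to an aromatic nitrogen.

On these data alone, whether a methoxy or an amine at this position would do the same remains open. So does whether fluoro would weaken compound 1, which carries 4-(trifluoromethyl)phenyl, to a similar degree.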